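The source may hold more compounds than are shown below. What is called first, only, known or untested is meant among the compounds shown, and "the series" means these compounds.

Series notes. Compound 1 `CCn1c(C(=O)NCCNC(=O)OC(C)(C)C)ccc1C(CC)(CC)c1ccc(OCS(=O)(=O)c2ccccc2)c(C)c1` carries a 2-((tert-butoxycarbonyl)amino)ethyl group on the amide-type nitrogen of the shared core. In a functional assay on MCF7 cells (Homo sapiens) for antiproliferative activity, read by MTT assay, with a stated time of 24 h (on this read-out higher numbers stand for weaker inhibition and lower numbers for stronger inhibition), compound 1 gives only a limit, > 50000 nM; this is the limit of > 50000 nM in this assay, at which 1 of the 3 values shown sits. Compound 2 `CCn1c(C(=O)N[C@@H](CO)C(C)C)ccc1C(CC)(CC)c1ccc(OCS(=O)(=O)c2ccccc2)c(C)c1` gives 18800 nM in this assay. Compound 3 `CCn1c(C(=O)NCCCO)ccc1C(CC)(CC)c1ccc(OCS(=O)(=O)c2ccccc2)c(C)c1` gives 42000 nM in this assay. Compound 4 `CCn1c(C(=O)N[C@@H](CO)CCCO)ccc1C(CC)(CC)c1ccc(OCS(=O)(=O)c2ccccc2)c(C)c1` is the next member: a group of 7 heavy atoms (5 carbon, 2 oxygen; no ring) in place of a group of 10 heavy atoms (7 carbon, 1 nitrogen, 2 oxygen; no ring), on an amide-type nitrogen. The entering group shares a hydroxymethyl with compound 2 and a hydroxypropyl chain with compound 3, so the steps of an at least 2.6-fold lower number from compound 1 to compound 2 (0.42 log units; beyond the scatter) and an at least 1.1-fold lower number from compound 1 to compound 3 (0.07 log units; that floor lies within the scatter) bear on it; between those two sits a 2.2-fold higher number from compound 2 to compound 3 (0.35 log units; beyond the scatter). A lower number than the limit of compound 1 is therefore expected, of at most modest size. Compound 4 is estimated at 30000 nM, range 12000 nM to 80000 nM, meaning an expected step of an at least 1.6-fold lower number from compound 1 to compound 4 (0.22 log units; that floor lies within the scatter).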

Compound 4, half-maximal inhibitory concentration: 29600 nM
The estimate for compound 4 lay 1.0-fold (0.01 log units) above the measured number, within the range that was stated.
By their numbers in this assay, from the lowest: compounds 2, 4 and 3 (each within the scatter of the next, the first and the last beyond it). At a limit, above all of these: compound 1.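

In this assay, 3-hydroxypropyl in place of isopropyl on the saturated chain carbon shows a 1.6-fold higher number from compound 2 to compound 4 (0.20 log units; within the scatter), and the larger group on the amide-type nitrogen shows a 1.4-fold lower number from compound 3 to compound 4 (0.15 log units; within the scatter). Neither step separates the new group from the two earlier hydroxyl-bearing groups at this position. Compound 1 gives only a limit, so the step to the new group is only a floor, an at least 1.6-fold lower number from compound 1 to compound 4 (0.22 log units; that floor lies within the scatter): the limit of > 50000 nM in this assay, at which 1 of the 4 values shown sits.

On these data alone, whether an amine, a carboxylic acid or a longer chain on this amide-type nitrogen would move the number beyond the scatter stays open.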